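Shifting the chlorine on the aryl amine of compound 3

The compounds below may be only part of what the source reports. "The series", "measured", "known", "first", "only" and "open" are said of these compounds alone.

Measured in a functional assay on MDA-MB-231 cells (Homo sapiens) for inhibition, read by MTT assay, with a stated time of 72 h; on this read-out lower numbers stand for stronger inhibition and higher numbers for weaker inhibition:
Compound 1, `O=C(CSc1nc(Nc2ccccc2)c2ccccc2n1)Nc1ccccc1Br`: 14100 nM
Compound 2, `C=CC(=O)Nc1cccc(NC(=O)CSc2nc(Nc3ccccc3C)c3ccccc3n2)c1`: 20400 nM
Compound 3, `C=CC(=O)Nc1cccc(NC(=O)CSc2nc(Nc3cccc(Cl)c3)c3ccccc3n2)c1`: 16300 nM

Compound 3 holds the second highest of the three numbers; compound 1 sits nearest, within the scatter, and compound 2 is separated from it only by a 1.3-fold lower number from compound 2 to compound 3 (0.10 log units; within the scatter). Compound 4, `C=CC(=O)Nc1cccc(NC(=O)CSc2nc(Nc3ccc(Cl)cc3)c3ccccc3n2)c1`, differs from compound 3 by 4-chlorophenyl in place of 3-chlorophenyl on a nitrogen on an aromatic ring. Within the data shown here, the single step that touches this nitrogen, from compound 2 to compound 3, exchanged one aryl group for another and stayed within the scatter; no step moves a chlorine around the ring. Compound 4 is therefore expected to show a 1.1-fold lower number from compound 3 to compound 4 (0.04 log units; within the scatter), nothing beyond the scatter. The estimate for compound 4 is 15000 nM, with a range from 7000 nM to 35000 nM.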

Compound 4, half-maximal inhibitory concentration: 10300 nM
For compound 4 the middle estimate is 1.5-fold (0.16 log units) above the measured one; the measured number falls inside the stated range.
By their numbers in this assay, from the lowest: compounds 4, 1, 3 and 2 (each within the scatter of the next).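

Exchanging 3-chlorophenyl for 4-chlorophenyl on this nitrogen gives a 1.6-fold lower number from compound 3 to compound 4 (0.20 log units; within the scatter) in this assay, so moving the chlorine around the ring does not carry the number out of the scatter. The change from 2-methylphenyl gives a 2.0-fold lower number from compound 2 to compound 4 (0.30 log units; within the scatter) and likewise leaves these aryl groups unranked. Nothing available explains these numbers.

From the compounds shown here alone, what remains open is whether a different group on this aryl ring, such as an amine or a carboxylic acid in place of the chlorine, would produce a step beyond the scatter.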